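The source may hold more compounds than are shown below. What is called first, only, known or untested is meant among the compounds shown, and "the series" means these compounds.

Measured in a functional assay on NMC-797 cells (Homo sapiens) for antiproliferative activity, with a stated time of 48 h; on this read-out lower numbers stand for stronger inhibition and higher numbers for weaker inhibition:
- Compound 1 `O=C1CC[C@]2(C[C@@H](c3cccc(C(F)(F)F)c3)O[C@@H](c3cccc(C(F)(F)F)c3)O2)O1` gives > 20000 nM as a limit of the assay, not a number
- Compound 2 `O=C1C=C[C@]2(C[C@@H](c3cccc([N+](=O)[O-])c3)O[C@@H](c3ccccc3)O2)O1` gives 160 nM
- Compound 3 `O=C1C=C[C@]2(C[C@@H](c3ccccc3)O[C@@H](c3cccc([N+](=O)[O-])c3)O2)O1` gives 120 nM

Compound 3 and compound 2 lie within the scatter of each other, so neither can be ranked ahead of the other. Compound 1 stands apart, since its entry is only a limit.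

Compound 4 `O=C1C=C[C@]2(C[C@@H](c3ccccc3)O[C@@H](c3ccccc3)O2)O1` is compound 3 with hydrogen in place of nitro on an aromatic carbon, meta to a large group (hydrogen in place of nitro on an aromatic carbon). Going by the values given here, no measured pair shows this change on its own, so its size can only be judged loosely. Among the compounds with values here, compound 2 at 160 nM and compound 3 at 120 nM each carry one nitro group, and no measured compound shows their core without it. A modest rise in the number in this assay is therefore expected, little beyond the scatter and possibly within it. The expected change is a 2.1-fold higher number from compound 3 to compound 4 (0.32 log units; beyond the scatter) and it remains an estimate. For compound 4 the estimated value is 250 nM with 70 nM to 900 nM as the expected range.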

Compound 4, half-maximal inhibitory concentration: 900 nM
Estimate against measurement, compound 4: 3.6-fold (0.56 log units) below, within the range that was stated.
By their numbers in this assay, from the lowest: compounds 3 and 2 (each within the scatter of the next); then compound 4. At a limit, above all of these: compound 1.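

In this assay, replacing the nitro group with hydrogen on an aromatic carbon, meta to a large group, produces a clear loss on both sides: a 7.5-fold higher number from compound 3 to compound 4 (0.88 log units; beyond the scatter), and likewise a 5.6-fold higher number from compound 2 to compound 4 (0.75 log units; beyond the scatter). Compound 2 and compound 3 could not be ranked against each other, but each now stands apart from compound 4, so a nitro group on either aromatic ring goes with a lower number than no nitro group at all. Nothing given here accounts for the size of these steps.

The compounds shown leave open whether another group in the same place, such as an amine, a nitrile or a carboxylic acid, would keep the lower number. They also leave open what a nitro group on both aromatic rings would give.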